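Aryl swap on the hydrazone of the shared core

This account rests on a few compounds, and the source may have more. Where it says the series, first, only, none or still open, it means among the compounds named here.

Measured compounds:
Compound 1 `CN(C)CCn1cnnc1-c1cc(Oc2ccc(NC(=O)N/N=C/c3ccc(F)cc3F)cc2F)ccn1`, 810 nM
Compound 2 `COc1ccc(/C=N/NC(=O)Nc2ccc(Oc3ccnc(-c4nncn4CCN(C)C)c3)c(F)c2)cc1O`, 2510 nM

Compound 2 gives the highest of the two numbers in a functional assay on MKN-45 cells (Homo sapiens) for cytotoxicity, read by MTT assay, with a stated time of 72 h; a lower number here means a stronger inhibitor, a higher number a weaker inhibitor; its nearest neighbour is compound 1, as the step of a 3.1-fold higher number from compound 1 to compound 2 (0.49 log units; beyond the scatter) shows. Compound 3 `CN(C)CCn1cnnc1-c1cc(Oc2ccc(NC(=O)N/N=C/c3ccc(F)cc3Cl)cc2F)ccn1` is not yet measured. It differs from compound 2 by 2-chloro-4-fluorophenyl in place of 3-hydroxy-4-methoxyphenyl on a carbon with a double bond to nitrogen. For the measured compounds named here, the only step that bears on this change is a 3.1-fold higher number from compound 1 to compound 2 (0.49 log units; beyond the scatter), which runs the other way, from a dihalogenated ring to the hydroxy-methoxy ring, with a modest rise. Compound 3 returns to a dihalogenated ring, so a modest drop is expected, a 3.3-fold lower number from compound 2 to compound 3 (0.52 log units; beyond the scatter). For compound 3 the estimate is 750 nM, in the range 250 nM to 2200 nM.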

Compound 3, half-maximal inhibitory concentration: 870 nM
Compound 3: middle estimate off by 1.2-fold (0.06 log units), on the low side; measured number inside the range.
By their numbers in this assay, from the lowest: compounds 1 and 3 (each within the scatter of the next); then compound 2.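

In this assay, a second dihalogenated ring on the carbon with a double bond to nitrogen also gives a lower number than the 3-hydroxy-4-methoxyphenyl group (a 2.9-fold lower number from compound 2 to compound 3 (0.46 log units; beyond the scatter)), so this gap is not tied to the 2,4-difluorophenyl group alone. Chloro in place of fluoro on an aromatic carbon changes nothing readable here (a 1.1-fold higher number from compound 1 to compound 3 (0.03 log units; within the scatter)). No measurement shown accounts for either step. Open, as far as these compounds go, is whether the hydroxy or the methoxy carries the higher number of compound 2. Also open, from the compounds shown here alone, is how an unsubstituted phenyl or a ring bearing an amine would read at this position.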